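This account rests on a few compounds, and the source may have more. Where it says the series, first, only, none or still open, it means among the compounds named here.

Measured so far:
compound 1, `COc1ccc(-c2cc(/C=C/C(=O)c3ccc(N)cc3)[nH]n2)cc1`: 2560 nM
compound 2, `COc1ccc(C(=O)/C=C/c2cc(-c3cc(OC)c(OC)c(OC)c3)n[nH]2)cc1OC`: 2570 nM

Both values come from a functional assay on UO-31 cells (Homo sapiens) for inhibition, read by sulforhodamine B assay, with a stated time of 48 h; on this read-out lower numbers stand for stronger inhibition of growth and higher numbers for weaker inhibition of growth. Going by the values given here, compound 1 and compound 2 sit within the usual scatter of each other, so neither can be set above the other; they also differ in more than one place, and no single step connects them. The next compound is compound 3, `COc1ccc(-c2cc(/C=C/C(=O)c3ccc(N)cc3)[nH]n2)cc1OC`, which differs from compound 1 by methoxy in place of hydrogen on an aromatic carbon. Whether that change alone moves the read-out cannot be told from the pair measured; compound 2 carries methoxy groups as well, but differs from compound 1 in several places and gives the same level. The step is therefore expected to be small, in no firm direction and not beyond the scatter, so that a 1.0-fold lower number from compound 1 to compound 3 (0.01 log units; within the scatter) is estimated near zero. For compound 3 the expected value in this assay is 2500 nM, with a range from 900 nM to 7000 nM.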

Compound 3, concentration for total growth inhibition: 13100 nM
Compound 3: the middle estimate sits 5.2-fold (0.72 log units) below what was measured; the whole stated range lies below it.
By their numbers in this assay, from the lowest: compounds 1 and 2 (each within the scatter of the next); then compound 3.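

In this assay, methoxy in place of hydrogen on this aromatic carbon, ortho to a methoxy group and meta to a large group, is not a silent change: a 5.1-fold higher number from compound 1 to compound 3 (0.71 log units; beyond the scatter), a modest loss of growth inhibition. Going by these compounds alone, the position therefore responds to substitution, at least with the rest of compound 1 held fixed, and this single pair is the only direct reading of the change. No measurement bears on why the added methoxy weakens inhibition.

As far as these compounds go, whether the loss belongs to methoxy itself or to any added group at this position remains open; a fluorine, a methyl or a hydroxyl on the same carbon would address that. Also open, from the compounds shown here alone, is whether the same step recurs when the amine of compound 1 gives way to an amide or a carboxylic acid.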